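The source may report more compounds than this note shows. Statements on the series, on what has been measured and on what is new or still open speak of the compounds shown alone.

Of the compounds shown here, three with a shared core have been measured in a functional assay on L1210 cells (Mus musculus); a lower number here means a stronger inhibitor, a higher number a weaker inhibitor. Compound 1 `CC(C)(C)C#Cc1cn(C2O[C@H](CO)[C@@H](O)[C@H]2O)c(=O)[nH]c1=O` gives 300 ug/mL in this assay, and compound 2 `CCCCCC#Cc1cn([C@H]2C[C@H](O)[C@@H](CO)O2)c(=O)[nH]c1=O` gives 219 ug/mL; these two numbers lie within the usual scatter of each other, so neither can be set apart from the other. For compound 3 `Cc1ccc(S(=O)(=O)OCCC#Cc2cn([C@H]3C[C@H](O)[C@@H](CO)O3)c(=O)[nH]c2=O)cc1` the result in this assay is only a limit, > 200 ug/mL, not a number. Compound 3 stands at the limit of > 200 ug/mL in this assay, at which 1 of the 3 values shown sits. Compound 4 `CC#Cc1cn([C@H]2C[C@H](O)[C@@H](CO)O2)c(=O)[nH]c1=O` is not yet measured. It differs from compound 2 by hydrogen in place of butyl on a saturated chain carbon bound to a triple-bonded carbon. Among the compounds with values here, no measured pair alters the chain at that place, so the data give no direction for this step; a change beyond the scatter either way cannot be excluded, and a limit is possible. Compound 4 is expected to give about 300 ug/mL in this assay, between 100 ug/mL and 1000 ug/mL. This estimate corresponds to an expected step of a 1.4-fold higher number from compound 2 to compound 4 (0.14 log units; within the scatter).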

Compound 4, concentration for 50% inhibition: 164 ug/mL
Estimate against measurement, compound 4: 1.8-fold (0.26 log units) above; the range from low to high includes it.
By their numbers in this assay, from the lowest: compounds 4, 2 and 1 (each within the scatter of the next).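

Going from butyl to hydrogen on a saturated chain carbon bound to a triple-bonded carbon gives a 1.3-fold lower number from compound 2 to compound 4 (0.13 log units; within the scatter) in this assay. Within the data shown here, this is the first measured pair that alters the chain at this place, and between hept-1-yn-1-yl and prop-1-yn-1-yl it shows no difference beyond the scatter. No measured property bears on this step.

As far as these compounds go, whether an amine, a carboxylic acid or a chain longer than hept-1-yn-1-yl at this place would move the number remains open. From the compounds shown here alone, the standing of compound 3 also stays open, since its result is only a limit.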